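Renal carcinoma growth series: chloro-fluoro phenyl variant

The source may hold more compounds than are shown below. What is called first, only, known or untested is meant among the compounds shown, and "the series" means these compounds.

Working notes. For the measured compounds named here, in a functional assay on cells (Panel renal (Carcinoma cell lines), Homo sapiens) for inhibition, read by sulforhodamine B assay, with a stated time of 48 h (a higher number here means a weaker inhibitor of growth, a lower number a stronger inhibitor of growth), compound 2 `CN1CCN(CCCOc2cccc3nc(Nc4cccc(Cl)c4)ccc23)CC1` gives 1900 nM, the lowest of the three numbers measured so far. Compound 3 `CN1CCN(CCCOc2cccc3nc(Nc4cc(Cl)cc(Cl)c4)ccc23)CC1` gives 2070 nM; the step of a 1.1-fold higher number from compound 2 to compound 3 (0.04 log units; within the scatter) lies within the scatter, so the two stand level. Compound 1 `CC(C)c1ccc(Nc2ccc3c(OCCCN4CCN(C)CC4)cccc3n2)cc1` gives 13200 nM; the steps of a 6.9-fold lower number from compound 1 to compound 2 (0.84 log units; beyond the scatter) and a 6.4-fold lower number from compound 1 to compound 3 (0.80 log units; beyond the scatter) are the only ones beyond the scatter in this set.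

Compound 4 `CN1CCN(CCCOc2cccc3nc(Nc4ccc(Cl)c(F)c4)ccc23)CC1` is not yet measured. Its change from compound 2: 4-chloro-3-fluorophenyl in place of 3-chlorophenyl on a nitrogen on an aromatic ring. Of the measured steps, a 1.1-fold higher number from compound 2 to compound 3 (0.04 log units; within the scatter) bears on it most nearly, since it also adds one chloro to the phenyl on the nitrogen and leaves the number where it was; the larger steps from compound 1 concern a different phenyl altogether and say little here. For compound 4 a step within the scatter is expected, a 1.1-fold higher number from compound 2 to compound 4 (0.02 log units; within the scatter), in no sure direction, because a 1.1-fold higher number from compound 2 to compound 3 (0.04 log units; within the scatter) stays within the scatter. For compound 4 the expected value in this assay is 2000 nM, within the range 800 nM to 5000 nM.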

Compound 4, concentration for 50% growth inhibition: 2220 nM
Compound 4: the middle estimate sits 1.1-fold (0.05 log units) below what was measured; the range from low to high includes it.
By their numbers in this assay, from the lowest: compounds 2, 3 and 4 (each within the scatter of the next); then compound 1.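

In this assay, 4-chloro-3-fluorophenyl in place of 3-chlorophenyl on the nitrogen gives a small step (a 1.2-fold higher number from compound 2 to compound 4 (0.07 log units; within the scatter)), and the same group in place of 3,5-dichlorophenyl gives another (a 1.1-fold higher number from compound 3 to compound 4 (0.03 log units; within the scatter)); both lie within the scatter, so a phenyl carrying fluoro stands level with the two carrying only chloro. The gap to the 4-isopropylphenyl of compound 1 also holds for this third halogen pattern (a 5.9-fold lower number from compound 1 to compound 4 (0.77 log units; beyond the scatter)), and compound 1 is the only one of the four set apart from the others. Nothing on hand accounts for either the level reading or this gap.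

Still open, as far as these compounds go, is where 4-chlorophenyl or 4-methoxyphenyl on this nitrogen would fall relative to compound 1 and compound 2. Also open, from the compounds shown here alone, is whether a cyclohexyl group there would stay level with compound 4.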